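This account rests on a few compounds, and the source may have more. Where it says the series, first, only, none or still open, it means among the compounds named here.

Working notes on the series. Of the compounds shown here, two carrying the 4-cyclohexylbutyl group have been read in a functional assay on HeLa cells (Homo sapiens) for inhibition, read by sulforhodamine B assay, with a stated time of 48 h; on this read-out higher numbers stand for weaker inhibition of growth and lower numbers for stronger inhibition of growth. Compound 1, `O=C(CCCCC1CCCCC1)OCC1COCCOCCOCCOCCO1`, gives > 100000 nM, and this is a limit of the assay and not a number. Among the compounds with values here, compound 2, `O=C(CCCCC1CCCCC1)OCC1COCCOCCOCCOCCOCCO1`, gives 71000 nM, which is the only true number so far, so it has no measured neighbour to be ranked against.

Compound 3, `O=C(OCC1COCCOCCOCCOCCOCCO1)c1cccnc1`, has not yet been measured. Its structural change from compound 2 is pyridin-3-yl in place of 4-cyclohexylbutyl on a carbonyl carbon. Within the data shown here, no measured step covers this kind of replacement, so what follows is judgement and not read-across.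

With compound 2 at 71000 nM as the single anchor in this assay, a clear gain in growth inhibition is not anticipated, and a move toward weaker inhibition is expected. The expected change is a 1.5-fold higher number from compound 2 to compound 3 (0.19 log units; within the scatter), and the reading may well come back as a limit and not a number. For compound 3 the estimated value is 110000 nM, with an expected range from 50000 nM to 220000 nM.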

Compound 3, concentration for 50% growth inhibition: > 100000 nM
Compound 3: only a limit was reported; the forecaster's own chance of this, stated with the estimate: 65%; the middle value is on the limit's open side.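

In this assay, replacing 4-cyclohexylbutyl with pyridin-3-yl on a carbonyl carbon gives the first step read at this position: an at least 1.4-fold higher number from compound 2 to compound 3 (0.14 log units; that floor lies within the scatter). Compound 3 gives > 100000 nM, which is a limit of the assay and not a number. The change therefore shows no gain in growth inhibition at this position, but the step can be read only as a floor, and compound 2 remains the only compound in the series with a true number: the limit of > 100000 nM in this assay, at which 2 of the 3 values shown sit.

As far as these compounds go, it remains open whether a phenyl group, a carbon-only aromatic ring, would read like pyridin-3-yl on the same carbonyl carbon, which would help separate the loss of 4-cyclohexylbutyl from the entry of the ring nitrogen. From the compounds shown here alone, it is also open whether a longer alkyl chain, an amine or a carboxylic acid at this place would give a true number in this assay, and whether any such number would lie clear of the scatter around compound 2.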